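Carbamoylmethyl in Place of Azidohydroxypropyl on a Nucleoside Core

The source may report more compounds than this note shows. Statements on the series, on what has been measured and on what is new or still open speak of the compounds shown alone.

Compound 1 `[N-]=[N+]=NCC(O)Cn1c(=O)n(C2OC(CO)[C@@H](O)[C@H]2O)c2nc(N)nc(O)c21` was examined in a functional assay (B cells) with Mus musculus as the target (a lower number here means that less compound is needed, a higher number that more compound is needed for the effect), where compound 1 gives 39 uM. Of the three numbers measured, compound 1 stands second highest. Its nearest neighbour is compound 2 `CCCn1c(=O)n(C2CCC(COC(C)=O)O2)c2nc(NC(C)=O)nc(O)c21`, which in this assay gives 154 uM, a higher number beyond the scatter. Furthest from it is compound 3 `C=CCn1c(=O)n(C2C=CC(CO)O2)c2nc(N)nc(O)c21`, which gives 6 uM, a lower number beyond the scatter. Compound 4 `NC(=O)Cn1c(=O)n(C2OC(CO)[C@@H](O)[C@H]2O)c2nc(N)nc(O)c21` has not yet been measured. It differs from compound 1 in one place: carbamoyl in place of 2-azido-1-hydroxyethyl on a saturated chain carbon bound to an aromatic nitrogen. Among the measured compounds shown here, no step between measured compounds carries this change, so its direction is uncertain; a modest shift toward a lower number is expected, the estimated step being a 1.6-fold lower number from compound 1 to compound 4 (0.19 log units; within the scatter). Compound 4 is estimated at 25 uM, within 8 uM to 100 uM.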

Compound 4, concentration for half-maximal effect: 190 uM
For compound 4 the middle estimate is 7.6-fold (0.88 log units) below the measured one, outside the stated range (above it).
By their numbers in this assay, from the lowest: compound 3; then compound 1; then compounds 2 and 4 (each within the scatter of the next).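

In this assay, among the compounds shown here, carbamoylmethyl in place of 3-azido-2-hydroxypropyl gives a 4.9-fold higher number from compound 1 to compound 4 (0.69 log units; beyond the scatter), the first single-change comparison at this position, and it shows that the group on this saturated chain carbon matters with the rest of the molecule held constant. Here, compound 1 with the azide-bearing chain needs less compound for the effect than compound 4 with the carbamoyl group. No measurement at hand explains the shift. Still open, on these data alone, is whether the azide, the hydroxyl or the chain length carries the difference. An amine or a carboxylic acid at the end of the chain could help separate these.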